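The compounds below may be only part of what the source reports. "The series", "measured", "known", "first", "only" and "open" are said of these compounds alone.

Three compounds share a core in which a piperidine-bound oxygen carries a carbamate; the first is compound 1 `Cc1nc(S(C)(=O)=O)ccc1Oc1ncnc(OC2CCN(C(=O)OC(C)C)CC2)c1F`, the second compound 2 `Cc1nc(S(C)(=O)=O)ccc1Oc1ncnc(OC2CCN(C(=O)OC(C)(C)C#N)CC2)c1F`, the third compound 3 `Cc1nc(S(C)(=O)=O)ccc1Oc1ncnc(OC2CCN(C(=O)OC3(C(F)(F)F)COC3)CC2)c1F`. In a functional assay on isolated protein for inhibition of Glucose-dependent insulinotropic receptor (Rattus norvegicus), read by HTRF and cAMP accumulation (a higher number here means a larger maximal response, a lower number a smaller maximal response), compound 1 gives 77%, compound 2 gives 97%, and compound 3 gives 84%. Compound 2 therefore stands highest of the three: the step of a number 20 percentage points higher from compound 1 to compound 2 (beyond the scatter) lies beyond the scatter, as does a number 13 percentage points lower from compound 2 to compound 3 (beyond the scatter), while a number 7 percentage points higher from compound 1 to compound 3 (within the scatter) stays within it.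

The account now turns to compound 4 `Cc1nc(S(C)(=O)=O)ccc1Oc1ncnc(OC2CCN(C(=S)OC(C)C)CC2)c1F`. Its difference from compound 2 is a group of 6 heavy atoms (4 carbon, 1 oxygen, 1 sulfur; no ring) in place of a group of 8 heavy atoms (5 carbon, 1 nitrogen, 2 oxygen; no ring), on an amine nitrogen in a ring. Two things happen at once: the nitrile-bearing branch is given up, and the carbonyl becomes a thiocarbonyl, so that the oxygen-bound part matches that of compound 1. Going by the values given here, the only measured step that bears on this is a number 20 percentage points higher from compound 1 to compound 2 (beyond the scatter), which shows what the nitrile contributes; undone, it would point to a loss of similar size. For the exchange of carbonyl for thiocarbonyl no comparison exists among the measured compounds. Because compound 1 gives 77%, compound 4 is expected to land close to it, with the step of a number 19 percentage points lower from compound 2 to compound 4 (beyond the scatter) estimated as a modest loss. Compound 4 is thus estimated at 78%, expected within 62% to 94%.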

Compound 4, largest response reached (reported as efficacy), in percent of the reference or control that the assay uses: 47%
The estimate for compound 4 lay 31 percentage points above the measured number, and the stated range ends above it.
By their numbers in this assay, from the lowest: compound 4; then compounds 1 and 3 (each within the scatter of the next); then compound 2.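

Compound 4 keeps the isopropyl group of compound 1 and exchanges only the carbonyl for a thiocarbonyl, and in this assay that single exchange gives a number 30 percentage points lower from compound 1 to compound 4 (beyond the scatter). Going by these compounds alone, this shows that the response at this amine nitrogen in a ring depends on the carbonyl itself, whereas the earlier compounds varied only the group on the oxygen. The steps of a number 50 percentage points lower from compound 2 to compound 4 (beyond the scatter) and a number 37 percentage points lower from compound 3 to compound 4 (beyond the scatter) leave compound 4 lowest of the four, but each combines the thiocarbonyl with a change of that oxygen-bound group, so neither can be divided between the two changes, and no measurement at hand explains the drop.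

The compounds shown leave open whether the thiocarbonyl would cost as much when paired with the 1-cyano-1-methylethyl group of compound 2 or the 3-(trifluoromethyl)oxetan-3-yl group of compound 3. They also leave open how a urea, with a nitrogen in place of the oxygen bound to the carbonyl, or a plain amide would compare on this amine nitrogen.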